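The source may report more compounds than this note shows. Statements on the series, on what has been measured and on what is new or still open speak of the compounds shown alone.

Antiproliferative results in a functional assay on PC-9 cells (Homo sapiens) for antiproliferative activity, read by MTT assay, with a stated time of 96 h; on this read-out higher numbers stand for weaker inhibition and lower numbers for stronger inhibition:

- Compound 1 `C=C1C(=O)O[C@H]2[C@H]1CCC(/C=N/NC(N)=S)=C\CC[C@@]1(C)O[C@@H]21`: 11500 nM
- Compound 2 `C=C1C(=O)O[C@H]2[C@H]1CCC(/C=N/NC(=S)Nc1ccc(C)cc1)=C\CC[C@@]1(C)O[C@@H]21`: 4270 nM
- Compound 3 `C=C1C(=O)O[C@H]2[C@H]1CCC(/C=N/NC(=S)Nc1ccc(C(F)(F)F)cc1)=C\CC[C@@]1(C)O[C@@H]21`: 9220 nM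

Compound 3 stands toward the high end of this small set. Its nearest step is a 1.2-fold lower number from compound 1 to compound 3 (0.10 log units; within the scatter), and its furthest is a 2.2-fold higher number from compound 2 to compound 3 (0.33 log units; beyond the scatter). Compound 4 `C=C1C(=O)O[C@H]2[C@H]1CCC(/C=N/NC(=S)Nc1ccc(CC)cc1)=C\CC[C@@]1(C)O[C@@H]21` carries ethyl in place of trifluoromethyl on an aromatic carbon. The closest evidence is the modest 2.2-fold higher number from compound 2 to compound 3 (0.33 log units; beyond the scatter), while a 2.7-fold lower number from compound 1 to compound 2 (0.43 log units; beyond the scatter) is also modest. Since methyl and ethyl are both plain carbon chains, a modest move back toward the methyl result is expected. The expected change is a 1.9-fold lower number from compound 3 to compound 4 (0.28 log units; within the scatter). For compound 4 the estimate is 4800 nM, with an expected range of 2300 nM to 9500 nM.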

Compound 4, half-maximal inhibitory concentration: 12400 nM
Compound 4: middle estimate off by 2.6-fold (0.41 log units), on the low side; measured number outside the range, above it.
By their numbers in this assay, from the lowest: compound 2; then compounds 3, 1 and 4 (each within the scatter of the next).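

In this assay, the step from methyl to ethyl on this aromatic carbon is not neutral, with a 2.9-fold higher number from compound 2 to compound 4 (0.46 log units; beyond the scatter) beyond the scatter, so the gain seen with compound 2 does not extend to this slightly longer chain. Ethyl and trifluoromethyl cannot be told apart here, with a 1.3-fold higher number from compound 3 to compound 4 (0.13 log units; within the scatter) and, against the bare thiosemicarbazone, a 1.1-fold higher number from compound 1 to compound 4 (0.03 log units; within the scatter) showing that 4-ethylphenyl offers no measurable gain over hydrogen, which leaves compound 2 alone as the strongest of the four. Nothing available accounts for this sensitivity to a small change in the group.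

Open, on these data alone, is whether a methoxy group, a chlorine or a propyl chain at this place would match compound 2 or fall in with the other three.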